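Notes on the amine terminus of compound 1

The source may hold more compounds than are shown below. What is called first, only, known or untested is meant among the compounds shown, and "the series" means these compounds.

Measured in an assay on isolated protein (Cavia porcellus) with Sigma non-opioid intracellular receptor 1 (Homo sapiens) as the target, read by radioligand binding; on this read-out lower numbers stand for stronger inhibition and higher numbers for weaker inhibition:
Compound 1 `CN(C)CCCCCCOc1ccc2oc(-c3ccccc3)cc(=O)c2c1`: 432 nM
Compound 2 `O=c1cc(-c2ccccc2)oc2ccc(OCCCN3CCC(O)CC3)cc12`: 130 nM
Compound 3 `O=c1cc(-c2ccccc2)oc2ccc(OCCCCCCN3CCCC(O)C3)cc12`: 86 nM

Compound 1 gives the highest of the three numbers. Both steps away from it are modest but beyond the scatter: a 3.3-fold lower number from compound 1 to compound 2 (0.52 log units; beyond the scatter) and a 5.0-fold lower number from compound 1 to compound 3 (0.70 log units; beyond the scatter). Compound 4 `CCN(CC)CCCCCCOc1ccc2oc(-c3ccccc3)cc(=O)c2c1` is not yet measured; it differs from compound 1 as follows: diethylamino in place of dimethylamino on a saturated chain carbon, six bonds along the chain from an oxygen on an aromatic ring. Neither measured step exchanges one dialkylamino group for another; both replace dimethylamino with a hydroxypiperidinyl ring, so they bear only loosely on this change. With so small a change in the entering group, the step is expected to stay within the scatter: a 1.4-fold lower number from compound 1 to compound 4 (0.13 log units; within the scatter). Compound 4 is therefore estimated at 320 nM, with a range of 120 nM to 850 nM in this assay.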

Compound 4, half-maximal inhibitory concentration: 91 nM
Beside the measured number, compound 4's estimate is 3.5-fold (0.55 log units) above it; the measured number lies below the stated range.
By their numbers in this assay, from the lowest: compounds 3, 4 and 2 (each within the scatter of the next); then compound 1.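

At the end of this six-bond chain, exchanging dimethylamino for diethylamino does register in this assay, with a 4.7-fold lower number from compound 1 to compound 4 (0.68 log units; beyond the scatter), so a change confined to the alkyl groups on the nitrogen can matter here. The open-chain diethylamino group also sits level with both hydroxypiperidinyl compounds, with a 1.1-fold higher number from compound 3 to compound 4 (0.02 log units; within the scatter) and a 1.4-fold lower number from compound 2 to compound 4 (0.15 log units; within the scatter), so among these compounds neither a ring nor a hydroxyl is required to reach this range. No supporting data explain the step.

Open, going by these compounds, is whether dipropylamino or diisopropylamino would extend the step from dimethylamino to diethylamino. Also open, on these data alone, is how diethylamino behaves on a propyl chain.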